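The compounds below may be only part of what the source reports. "The series", "measured", "known", "first", "only" and "open" are said of these compounds alone.

Measured compounds in a functional assay on M21 cells (Homo sapiens) for antiproliferative activity, read by sulforhodamine B assay, with a stated time of 48 h; on this read-out lower numbers stand for stronger inhibition of growth and higher numbers for weaker inhibition of growth:
- compound 1 `NS(=O)(=O)NCC1CCN(c2cc(-c3ccccc3)ncn2)CC1` gives > 100000 nM, a limit of the assay.
- compound 2 `COc1ccc(-c2cc(N3CCC(CNS(N)(=O)=O)CC3)ncn2)cc1` gives > 100000 nM, likewise a limit.
- compound 3 `CCOC(=O)c1ccc(-c2cc(N3CCC(CNS(N)(=O)=O)CC3)ncn2)cc1` gives 5000 nM.

Compound 2 thus stands at the upper limit of this assay, and (the limit of > 100000 nM in this assay, at which 2 of the 3 values shown sit); no number is recorded for it. The step that the two limits leave unreadable from compound 1 to compound 2 cannot be read for that reason. Only the ethoxycarbonyl compound gives a number: the steps of an at least 20-fold lower number from compound 1 to compound 3 (1.30 log units; beyond the scatter) and an at least 20-fold lower number from compound 2 to compound 3 (1.30 log units; beyond the scatter) are both large.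

Compound 4 `NS(=O)(=O)NCC1CCN(c2cc(-c3cccc(Cl)c3)ncn2)CC1` is not yet measured. It differs from compound 2 in one place: 3-chlorophenyl in place of 4-methoxyphenyl on an aromatic carbon. Neither measured step bears directly on a chlorine on the phenyl ring; the unsubstituted phenyl of compound 1 and the methoxyphenyl of compound 2 both sit at the limit, and only the ethoxycarbonyl of compound 3 moves off it. Chlorophenyl is none of these, so the expectation in this assay is a small step at most, with a fair chance that compound 4 is again reported only as a limit. Compound 4 is estimated at 80000 nM, within 15000 nM to 400000 nM, which corresponds to an expected step of an at least 1.2-fold lower number from compound 2 to compound 4 (0.09 log units; that floor lies within the scatter).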

Compound 4, concentration for 50% growth inhibition: 62500 nM
Beside the measured number, compound 4's estimate is 1.3-fold (0.11 log units) above it; the range from low to high includes it.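

In this assay, within the data shown here, compound 4 is the second compound here with a number rather than a limit, after compound 3, so ethoxycarbonyl is no longer the only group on the phenyl ring that moves the read-out off the limit. The steps are an at least 1.6-fold lower number from compound 1 to compound 4 (0.20 log units; that floor lies within the scatter) and an at least 1.6-fold lower number from compound 2 to compound 4 (0.20 log units; that floor lies within the scatter); both are floors only, and as floors within the scatter they do not by themselves establish a real gain for 3-chlorophenyl over phenyl or 4-methoxyphenyl. The true size of both steps stays unreadable, since compound 1 and compound 2 each hold only a limit: the limit of > 100000 nM in this assay, at which 2 of the 4 values shown sit.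

As far as these compounds go, what a carboxylic acid or a primary amide would give in place of the ethoxycarbonyl on the phenyl ring stays open, and with it whether the number of compound 3 depends on the ester itself. Also open, from the compounds shown here alone, is whether chloro on another carbon of the phenyl ring, or a second chloro, would give a number clearly apart from the limit on the shared core.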